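The source may hold more compounds than are shown below. What is called first, only, known or untested is meant among the compounds shown, and "the series" means these compounds.

The measured compounds and their readings:
compound 1, `CC1=CC[C@@H]([C@@](C)(O)CCCC(C)(C)NC=S)CC1`: 11000 nM
compound 2, `CC1=CC[C@@H]([C@@](C)(O)CCCC(C)(C)NC(=S)NN)CC1`: 26800 nM
compound 3, `CC1=CC[C@@H]([C@@](C)(O)CCCC(C)(C)NC(=S)N/N=C\c2ccc(C)cc2)CC1`: 6750 nM

All three were tested in a functional assay on PCO3 cells (Homo sapiens) for cytotoxicity, read by sulforhodamine B assay; on this read-out lower numbers stand for stronger inhibition of growth and higher numbers for weaker inhibition of growth. Compound 2 stands at the highest number of the three, meaning the weakest inhibition of growth: compound 1 sits at a lower number, and compound 3 at the lowest. The two measured steps show how changes at the thiocarbonyl end of the shared core move the reading. Adding aminoamino to the thiocarbonyl carbon gave a 2.4-fold higher number from compound 1 to compound 2 (0.39 log units; beyond the scatter), a weakening. Building out from that amino group with an aromatic ring gave a 4.0-fold lower number from compound 2 to compound 3 (0.60 log units; beyond the scatter), a strengthening that more than undid the first step.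

Compound 4, `COc1ccc(/C=N\NC(=S)NC(C)(C)CCC[C@](C)(O)[C@@H]2CC=C(C)CC2)cc1`, has not yet been measured. It differs from compound 2 as follows: a group of 10 heavy atoms (8 carbon, 1 nitrogen, 1 oxygen; one six-membered aromatic ring of carbon only) in place of one nitrogen atom, on an amide-type nitrogen. Among the compounds with values here, this is the same kind of change as the one from compound 2 to compound 3, with an oxygen added to the aromatic ring; the step from compound 2 to compound 3 is therefore the only one that bears on it, and it was a modest lowering beyond the scatter. A step of about that size in the same direction is expected here, a 4.1-fold lower number from compound 2 to compound 4 (0.62 log units; beyond the scatter), so compound 4 is estimated at 6500 nM, likely between 2500 nM and 16000 nM.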

Compound 4, concentration for 50% growth inhibition: 7660 nM
Estimate against measurement, compound 4: 1.2-fold (0.07 log units) below; low and high end bracket the measured number.
By their numbers in this assay, from the lowest: compounds 3, 4 and 1 (each within the scatter of the next); then compound 2.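

In this assay compound 4 shows that the lowering seen with compound 3 is not limited to one ring-bearing group: placing its larger group on the amide-type nitrogen, in place of the amino of compound 2, gives a 3.5-fold lower number from compound 2 to compound 4 (0.54 log units; beyond the scatter) and again lies beyond the scatter. The new comparison also tests the group carried on the aromatic ring, and the change gives a 1.1-fold higher number from compound 3 to compound 4 (0.05 log units; within the scatter) on this read-out, which lies within the scatter, so methoxy and methyl on that aromatic carbon cannot be told apart here. Across these compounds, then, the step from the amino to a ring-bearing group is the change that registers, while this swap on the ring does not. Nothing available here explains why either change has the result it does.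

From the compounds shown here alone, only methyl and methoxy have been seen on the aromatic ring, so it remains open whether a fluorine, a hydroxyl, a nitro group or a dimethylamino group would move the number beyond the scatter. Going by these compounds, it is also open whether the ring itself is needed, or whether a pyridine ring or a plain isopropyl group in its place would give a similar reading.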